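Swapping the pyridine ring of compound 2 for cyclohexyl

The source may hold more compounds than are shown below. What is called first, only, known or untested is meant among the compounds shown, and "the series" means these compounds.

Measured so far:
Compound 1, `Cn1c(=O)c(OCc2ccc(C(=O)NO)cc2)c(-c2ccccc2)c2ccccc21`: 519 nM
Compound 2, `Cn1c(=O)c(OCc2ccc(C(=O)NO)cc2)c(-c2cccnc2)c2ccccc21`: 46 nM
Compound 3, `O=C(NO)c1ccc(COc2c(-c3cccnc3)c3ccccc3n(Cc3ccncc3)c2=O)cc1`: 45.3 nM

All three were tested in an assay on Sf9 cells for inhibition of protein deacetylase HDAC6 (Homo sapiens), read by fluorescence, with a stated time of 90 min; on this read-out lower numbers stand for stronger inhibition and higher numbers for weaker inhibition. Compound 2 stands second highest of the three numbers. Its nearest neighbour is compound 3, separated by a 1.0-fold lower number from compound 2 to compound 3 (0.01 log units; within the scatter), a gap within the scatter. Within the data shown here, its furthest neighbour is compound 1, and the step of an 11-fold lower number from compound 1 to compound 2 (1.05 log units; beyond the scatter) is the only large change seen so far; it came with pyridin-3-yl in place of phenyl.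

Compound 4, `Cn1c(=O)c(OCc2ccc(C(=O)NO)cc2)c(C2CCCCC2)c2ccccc21`, has not yet been measured. It differs from compound 2 by cyclohexyl in place of pyridin-3-yl on an aromatic carbon. Among the measured compounds shown here, only one measured step bears on this change: an 11-fold lower number from compound 1 to compound 2 (1.05 log units; beyond the scatter), where adding the ring nitrogen at this very position brought a large gain. Compound 4 removes that nitrogen again, and the ring is no longer aromatic, so much of that gain is expected to be lost. The step of a 1.0-fold lower number from compound 2 to compound 3 (0.01 log units; within the scatter) concerns a different position and is within the scatter, so it gives no guidance here. In this assay compound 4 is therefore expected to give 400 nM, within a range from 100 nM to 1600 nM. That estimate means an 8.7-fold higher number from compound 2 to compound 4 (0.94 log units; beyond the scatter), a step expected to lie beyond the scatter toward weaker inhibition.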

Compound 4, half-maximal inhibitory concentration: 33 nM
Beside the measured number, compound 4's estimate is 12-fold (1.08 log units) above it; the measured number lies below the stated range.
By their numbers in this assay, from the lowest: compounds 4, 3 and 2 (each within the scatter of the next); then compound 1.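

In this assay, cyclohexyl in place of pyridin-3-yl gives a 1.4-fold lower number from compound 2 to compound 4 (0.14 log units; within the scatter), so at this position neither a ring nitrogen nor an aromatic ring is needed for a number in this range. Cyclohexyl in place of phenyl gives a 16-fold lower number from compound 1 to compound 4 (1.20 log units; beyond the scatter), a large step, so the gain first seen with pyridin-3-yl cannot be credited simply to the ring nitrogen: a ring of carbon only can do as well, and phenyl is the group that stands apart among the three. Nothing measured here explains why phenyl differs from the other two rings.

The compounds shown leave open whether a ring is needed here at all, which an open chain such as n-butyl would test. They also leave open how a smaller ring such as cyclopropyl, or a saturated ring holding nitrogen such as piperidin-4-yl, would compare.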